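Furan Aryl Series: Extending the Ether Toward Trifluoroethoxy

The compounds below may be only part of what the source reports. "The series", "measured", "known", "first", "only" and "open" are said of these compounds alone.

Measured compounds:
compound 1, `CCOC(=O)c1c(C)coc1-c1ccc2c(CC)cccc2c1OC`, 3.8 ug/mL
compound 2, `CCc1cccc2c(OC)c(-c3occ(C)c3CO)ccc12`, 9.6 ug/mL
compound 3, `CCc1cccc2c(OC)c(-c3occ(C)c3COC)ccc12`, > 10 ug/mL

In a functional assay on A549 cells (Homo sapiens) for cytotoxicity, read by MTT assay, with a stated time of 72 h (a higher number here means that more compound is needed for the effect, a lower number that less compound is needed), compound 1 gives 3.8 ug/mL and compound 2 gives 9.6 ug/mL. For compound 3 only a limit is reported, > 10 ug/mL, which is the limit of > 10 ug/mL in this assay, at which 1 of the 3 values shown sits. Compound 3 thus stands at the weak end of the numbers shown, without an exact value. The steps of a 2.5-fold higher number from compound 1 to compound 2 (0.40 log units; beyond the scatter) and an at least 2.6-fold higher number from compound 1 to compound 3 (0.42 log units; beyond the scatter) both raised the number, whereas an at least 1.0-fold higher number from compound 2 to compound 3 (0.01 log units; that floor lies within the scatter) has a floor inside the scatter. Compound 4, `CCc1cccc2c(OC)c(-c3occ(C)c3COCC(F)(F)F)ccc12`, differs from compound 3 by trifluoromethyl in place of hydrogen on a saturated chain carbon bound to an oxygen on a saturated carbon. Within the data shown here, no measured step touches this part of the chain, and the nearest one, the methylation of the oxygen, gave no direction beyond the scatter. Compound 4 is therefore expected to give about 12 ug/mL in this assay, between 5 ug/mL and 30 ug/mL, so the expected step that the limit leaves unreadable from compound 3 to compound 4 is no change beyond the scatter, most likely again a limit.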

Compound 4, concentration for half-maximal effect: > 10 ug/mL
Compound 4: no number, only a limit; the forecaster's own chance of this, stated with the estimate: 65%; the middle value lies beyond the limit too.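

In this assay, compound 4 gives only a limit, > 10 ug/mL. Replacing ethoxycarbonyl on an aromatic carbon with (2,2,2-trifluoroethoxy)methyl gives an at least 2.6-fold higher number from compound 1 to compound 4 (0.42 log units; beyond the scatter), so a second ether chain also fails to restore the number of compound 1, while adding 2,2,2-trifluoroethyl on the oxygen gives an at least 1.0-fold higher number from compound 2 to compound 4 (0.01 log units; that floor lies within the scatter). The step between the two limited compounds cannot be read: the limit of > 10 ug/mL in this assay, at which 2 of the 4 values shown sit.

As far as these compounds go, whether an amine or a carboxylic acid in place of the trifluoromethyl, or a longer chain, would move the number back toward that of compound 1 stays open. So does the true distance between compound 3 and compound 4.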